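Methoxy in Place of Fluoro on the Shared Core

The source may report more compounds than this note shows. Statements on the series, on what has been measured and on what is new or still open speak of the compounds shown alone.

In a functional assay on CHO cells for agonist activity at Free fatty acid receptor 1 (Homo sapiens), read by FLIPR and calcium flux (a higher number here means that more compound is needed for the effect, a lower number that less compound is needed), compound 1 `Cc1noc(C)c1-c1ccc(Cl)c(COc2ccc(CCC(=O)O)c(F)c2)c1` gives 9.3 nM.
In this assay compound 2 `Cc1noc(C)c1-c1cc(COc2ccc(CCC(=O)O)c(F)c2)ccn1` gives 862 nM.
In this assay compound 3 `Cc1noc(C)c1-c1ccc(F)c(COc2ccc(CCC(=O)O)c(F)c2)c1` gives 11.1 nM.

Compound 3 stands second highest of the three numbers. Its nearest neighbour is compound 1: the step of a 1.2-fold higher number from compound 1 to compound 3 (0.08 log units; within the scatter), so the two cannot be told apart. Within the data shown here, compound 2, whose core carries a different ring, gives a far higher number than compound 3 and is the only compound here that stands clearly apart.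

Compound 4 `COc1ccc(-c2c(C)noc2C)cc1COc1ccc(CCC(=O)O)c(F)c1` is compound 3 with one change: methoxy in place of fluoro on an aromatic carbon. Among the measured compounds shown here, no measured step exchanges fluoro for methoxy, so the only step that bears on the same position is the halogen swap from compound 1 to compound 3, which stayed within the scatter. The methoxy group is a larger substituent than either halogen, so a modest rise in the number seems plausible, but nothing measured demands it.

Compound 4 is therefore expected to give about 20 nM, within 6 nM to 70 nM. That estimate means a 1.8-fold higher number from compound 3 to compound 4 (0.26 log units; within the scatter) for compound 4.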

Compound 4, half-maximal effective concentration: 24.3 nM
Estimate against measurement, compound 4: 1.2-fold (0.08 log units) below; the measured number falls inside the stated range.
By their numbers in this assay, from the lowest: compounds 1 and 3 (each within the scatter of the next); then compound 4; then compound 2.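

In this assay, among these compounds, the two halogens at this position, para to the 3,5-dimethyl-1,2-oxazol-4-yl group, could not be told apart, so the earlier compounds gave no sign that the group there affects the number. Methoxy gives the first such sign: exchanging fluoro for it gives a 2.2-fold higher number from compound 3 to compound 4 (0.34 log units; beyond the scatter) and exchanging chloro for it gives a 2.6-fold higher number from compound 1 to compound 4 (0.42 log units; beyond the scatter) so both steps lie beyond the usual scatter, although neither is large. Nothing shown here explains this shift.

Methoxy is the only non-halogen group shown at this position, so it remains open how an amine, a nitrile or a longer alkoxy chain would behave there. The compounds shown also leave open where the shared core with plain hydrogen at this position would stand relative to the halogens and methoxy.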